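Chloro to methoxy on the pyrazole of compound 2

The source may report more compounds than this note shows. Statements on the series, on what has been measured and on what is new or still open speak of the compounds shown alone.

Measured in a functional assay on cells for antagonist activity at Glucagon receptor (Homo sapiens), read by cAMP accumulation, in the presence of a further agent that is not named here; a lower number here means a stronger inhibitor, a higher number a weaker inhibitor:
compound 1 `CCCC(Oc1ccc(-n2cc(C(F)(F)F)cn2)c(C)c1)c1ccc(C(=O)NCCC(=O)O)cc1` gives 1900 nM
compound 2 `CCCC(Oc1ccc(-n2cc(Cl)cn2)cc1)c1ccc(C(=O)NCCC(=O)O)cc1` gives 6500 nM
compound 3 `CCCC(Nc1ccc(-n2cc(C(F)(F)F)cn2)nc1)c1ccc(C(=O)NCCC(=O)O)cc1` gives 1300 nM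

Compound 2 has the highest number of the three in this assay; its gap to compound 1 and its larger gap to compound 3 both lie beyond the scatter. Compound 4 `CCCC(Oc1ccc(-n2cc(OC)cn2)cc1)c1ccc(C(=O)NCCC(=O)O)cc1` is not yet measured. It differs from compound 2 in one place: methoxy in place of chloro on an aromatic carbon, that is, 4-chloro-1H-pyrazol-1-yl to 4-methoxy-1H-pyrazol-1-yl. Among the compounds with values here, no measured pair shows this change, so nothing anchors its size. The step of a 1.2-fold higher number from compound 2 to compound 4 (0.09 log units; within the scatter) is expected to stay within the scatter, with a slight lean towards a higher number. Compound 4 is estimated at 8000 nM in this assay, in the range 3000 nM to 25000 nM.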

Compound 4, antagonist equilibrium constant: > 23000 nM
Compound 4 gave a limit, no number; the forecaster's own chance of this, stated with the estimate: 15%; middle value at least 2.8-fold (0.45 log units) from the limit.
By their numbers in this assay, from the lowest: compounds 3 and 1 (each within the scatter of the next); then compound 2. At a limit, above all of these: compound 4.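

Methoxy in place of chloro on this aromatic carbon of the shared core gives an at least 3.5-fold higher number from compound 2 to compound 4 (0.54 log units; beyond the scatter) in this assay. Within the data shown here, this is the first sign that a single group change at this position can move the read-out beyond the scatter, which the earlier compounds, differing in more than one place, could not show. Compound 4 gives > 23000 nM, which is a limit of the assay and not a number.

The compounds shown leave open how a methyl, an ethoxy or a nitrile on this carbon would read. They therefore cannot tell whether the step goes with the oxygen of methoxy or with its extra heavy atom.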